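The compounds below may be only part of what the source reports. "The series", "measured", "known", "first", "only" and "open" are said of these compounds alone.

Measured compounds:
- compound 1, `O=C(Nc1ccc(-n2ncc3c(Cl)cccc32)cc1)Nc1ccc(Cl)c(C(F)(F)F)c1` — 4600 nM
- compound 2, `O=C(Nc1ccc(-n2ncc3c(C(F)(F)F)cccc32)cc1)Nc1ccc(C(F)(F)F)cc1` — 3300 nM
- compound 3, `O=C(Nc1ccc(-n2ncc3c(Cl)cccc32)cc1)Nc1ccc(C(F)(F)F)cc1` — 1000 nM

In a functional assay on HT-29 cells (Homo sapiens) for cytotoxicity, read by MTT assay, with a stated time of 72 h (a lower number here means a stronger inhibitor, a higher number a weaker inhibitor), compound 1 gives the highest of the three numbers. Compound 2 lies within the scatter of it, so the two cannot be ordered; compound 3 stands clearly apart, with a number well beyond the scatter from compound 1. Within the data shown here, the one single-point step in this set is a 3.3-fold lower number from compound 2 to compound 3 (0.52 log units; beyond the scatter), which concerns the substituent on the bicyclic ring of the shared core. Compound 4, `O=C(Nc1ccc(-n2ncc3ccncc32)cc1)Nc1ccc(Cl)c(C(F)(F)F)c1`, is not yet measured. It differs from compound 1 by a group of 9 heavy atoms (6 carbon, 3 nitrogen; one five-membered aromatic ring with 2 hetero atoms, one six-membered aromatic ring with 1 hetero atom) in place of a group of 10 heavy atoms (7 carbon, 2 nitrogen, 1 chlorine; one five-membered aromatic ring with 2 hetero atoms, one six-membered aromatic ring of carbon only), on an aromatic carbon. Among the measured compounds shown here, no measured step covers this exchange: the step from compound 2 to compound 3 shows that a change on that bicyclic ring can shift the number modestly, but it does not say in which direction the present change would act. Compound 4 is therefore expected to land close to compound 1, with a 1.1-fold higher number from compound 1 to compound 4 (0.04 log units; within the scatter) as a guess and a wide range. The estimate for compound 4 is 5000 nM, between 1500 nM and 20000 nM.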

Compound 4, half-maximal inhibitory concentration: 29500 nM
The estimate for compound 4 lay 5.9-fold (0.77 log units) below the measured number; the whole stated range lies below it.
By their numbers in this assay, from the lowest: compound 3; then compounds 2 and 1 (each within the scatter of the next); then compound 4.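

In this assay, replacing the 4-chloro-1H-indazol-1-yl group with the group whose six-membered aromatic ring holds a hetero atom gives a 6.4-fold higher number from compound 1 to compound 4 (0.81 log units; beyond the scatter). The earlier step on this part of the molecule only exchanged one substituent for another, a 3.3-fold lower number from compound 2 to compound 3 (0.52 log units; beyond the scatter), whereas this one shows that the number also responds when the chlorine is lost and the six-membered ring itself changes, and it fixes the direction of this exchange as upward. No measurement shown here accounts for this shift.

The chlorine leaves and the ring hetero atom enters in the same exchange, and the compounds shown do not separate the two changes. As far as these compounds go, how a fluorine or a methoxy group on this ring would read, with or without the ring nitrogen, also remains open.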